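This account rests on a few compounds, and the source may have more. Where it says the series, first, only, none or still open, it means among the compounds named here.

Measured so far in a functional assay on SMMC-7721 cells (Homo sapiens) for cytotoxicity, read by MTT assay, with a stated time of 24 h; a lower number here means a stronger inhibitor, a higher number a weaker inhibitor:
- compound 1 `CN1C/C(=C\c2ccncc2)C(=O)/C(=C/c2ccccc2C(F)(F)F)C1`: 4100 nM
- compound 2 `O=C1/C(=C/c2ccncc2)CN(S(=O)(=O)c2ccc(Cl)cc2)C/C1=C\c1ccccc1C(F)(F)F`: 5510 nM

In this assay compound 2 gives 5510 nM, which lies within the scatter of compound 1, so the two numbers are not separated. Next in the series is compound 3 `O=C1/C(=C/c2ccncc2)CN(S(=O)(=O)c2ccc(Br)cc2)C/C1=C\c1ccccc1C(F)(F)F`. Its difference from compound 2 is bromo in place of chloro on an aromatic carbon. In words, this is bromo in place of chloro on an aromatic carbon, para to a large group, turning 4-chlorophenyl into 4-bromophenyl.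

Going by the values given here, only one measured step bears on this change: a 1.3-fold higher number from compound 1 to compound 2 (0.13 log units; within the scatter). That step replaced methyl with (4-chlorophenyl)sulfonyl on the ring nitrogen, a far larger exchange than a single halogen, and it stayed within the scatter. Among the compounds with values here, no measured pair swaps one halogen for another, so the evidence is indirect. No direction can be assigned, and no shift beyond the scatter is expected in this assay. The expected step is a 1.0-fold lower number from compound 2 to compound 3 (0.02 log units; within the scatter). For compound 3 the estimate is 5300 nM, with an expected range of 2800 nM to 10000 nM.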

Compound 3, half-maximal inhibitory concentration: 10500 nM
Compound 3: middle estimate off by 2.0-fold (0.30 log units), on the low side; the whole stated range lies below it.
By their numbers in this assay, from the lowest: compounds 1, 2 and 3 (each within the scatter of the next, the first and the last beyond it).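

In this assay the exchange of chloro for bromo on the aromatic carbon gives a 1.9-fold higher number from compound 2 to compound 3 (0.28 log units; within the scatter) and so leaves compound 2 and compound 3 unseparated, which means the halogen at this place has no resolved effect on its own. The series does show its first separated pair when methyl on the ring nitrogen gives way to (4-bromophenyl)sulfonyl, with a 2.6-fold higher number from compound 1 to compound 3 (0.41 log units; beyond the scatter) as the reading, while the corresponding (4-chlorophenyl)sulfonyl exchange gave a 1.3-fold higher number from compound 1 to compound 2 (0.13 log units; within the scatter) and stayed unresolved, so the separation rests on compound 3 alone and is modest. No available measurement accounts for this difference between the two sulfonyl exchanges.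

Going by these compounds, whether fluoro, iodo or methoxy on the same aromatic carbon, or an unsubstituted phenylsulfonyl on the ring nitrogen, would fall nearer compound 1 or compound 3 remains open. Also open, on these data alone, is whether an acetyl or benzyl group on that nitrogen would give a separation from compound 1 like that of compound 3, since the shared core has so far carried only methyl and these two arylsulfonyl groups there.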